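The source may hold more compounds than are shown below. What is called first, only, known or untested is meant among the compounds shown, and "the series" means these compounds.

Measured so far in a functional assay on HL-60 cells (Homo sapiens) for inhibition, read by CCK-8 assay, with a stated time of 48 h; a lower number here means a stronger inhibitor, a higher number a weaker inhibitor:
- compound 1 `COc1ccc(S(=O)(=O)Oc2ccccc2/C=C(\C#N)C(=O)Nc2nnc(-c3cccs3)s2)cc1`: 5230 nM
- compound 2 `COc1ccc(S(=O)(=O)Oc2ccccc2/C=C(\C#N)C(=O)Nc2nnc(Cc3cccc4ccccc34)s2)cc1`: 4700 nM
- compound 3 `COc1ccc(S(=O)(=O)Oc2ccccc2/C=C(\C#N)C(=O)Nc2nnc(Cc3ccccc3)s2)cc1`: 3170 nM

In this assay compound 3 gives 3170 nM, a value within the scatter of those of both other compounds, so no order can be read among the three.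

Compound 4 `COc1ccc(S(=O)(=O)Oc2ccccc2/C=C(\C#N)C(=O)Nc2nnc(Cc3ccc(F)cc3)s2)cc1` keeps the shared core and turns benzyl into 4-fluorobenzyl: fluoro in place of hydrogen on an aromatic carbon of a six-membered aromatic ring of carbon only, para to a large group (fluoro in place of hydrogen on an aromatic carbon).

Among the compounds with values here, no measured step adds fluoro, so the evidence is indirect. All three measured steps change the same substituent: a 1.5-fold lower number from compound 2 to compound 3 (0.17 log units; within the scatter), a 1.6-fold lower number from compound 1 to compound 3 (0.22 log units; within the scatter) and a 1.1-fold lower number from compound 1 to compound 2 (0.05 log units; within the scatter). Each stays within the scatter, so no shift beyond the scatter is expected in this assay, and no direction is favoured.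

The estimated step is a 1.1-fold lower number from compound 3 to compound 4 (0.04 log units; within the scatter), which is expected to remain within the scatter.

For compound 4 the expected value is 2900 nM, with an estimated range of 1400 nM to 5600 nM.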

Compound 4, half-maximal inhibitory concentration: 4050 nM
Estimate against measurement, compound 4: 1.4-fold (0.15 log units) below; the measured number falls inside the stated range.
By their numbers in this assay, from the lowest: compounds 3, 4, 2 and 1 (each within the scatter of the next).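

In this assay, fluoro in place of hydrogen on an aromatic carbon, para to a large group, gives a 1.3-fold higher number from compound 3 to compound 4 (0.11 log units; within the scatter), so this first change on the phenyl ring of benzyl leaves the number within the scatter. The 4-fluorobenzyl group also shows no separation from the other substituents at this position, with a 1.2-fold lower number from compound 2 to compound 4 (0.06 log units; within the scatter) and a 1.3-fold lower number from compound 1 to compound 4 (0.11 log units; within the scatter), so the four compounds still cannot be ordered. Nothing available explains why the number holds under this change.

On these data alone, it remains open whether any change at this position can move the number beyond the scatter. An amine or a carboxylic acid in place of fluoro, or a longer chain in place of benzyl, would test this more widely.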